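From Methyl to Pyrrol-2-yl: Estimating Compound 4

The source may report more compounds than this note shows. Statements on the series, on what has been measured and on what is new or still open speak of the compounds shown alone.

Compound 1 `COC(=O)c1nc(C)n(-c2ccc(C(F)(F)F)cc2)n1`: 9100 nM
Compound 2 `COC(=O)c1nc(C)n(-c2ccc(OC)cc2)n1`: > 100000 nM, a limit of the assay
Compound 3 `COC(=O)c1nc(C)n(-c2ccc(Cl)cc2)n1`: 65900 nM

All three were tested in a functional assay on Jurkat cells (Homo sapiens) for inhibition, read by MTT assay, with a stated time of 72 h; a higher number here means a weaker inhibitor of growth, a lower number a stronger inhibitor of growth. Among the numbers shown, compound 1 stands lowest, with compound 3 as its nearest neighbour: a 7.2-fold higher number from compound 1 to compound 3 (0.86 log units; beyond the scatter). For compound 2 the assay reports only a limit (the limit of > 100000 nM in this assay, at which 1 of the 3 values shown sits), so the comparison an at least 10-fold higher number from compound 1 to compound 2 (1.04 log units; beyond the scatter) is a floor rather than an exact size. The remaining comparison, an at least 1.5-fold lower number from compound 2 to compound 3 (0.18 log units; that floor lies within the scatter), cannot be separated from the scatter.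

Compound 4 `COC(=O)c1nc(-c2ccc[nH]2)n(-c2ccc(C(F)(F)F)cc2)n1` differs from compound 1 by 1H-pyrrol-2-yl in place of methyl on an aromatic carbon. Going by the values given here, none of the measured steps touch this part of the shared core; each of them swaps the trifluoromethyl group elsewhere in the molecule. The measured data therefore give no direction for this change, and no large step is expected either way. The expected step is a 1.1-fold lower number from compound 1 to compound 4 (0.06 log units; within the scatter). Compound 4 is estimated at 8000 nM, within a range of 1500 nM to 45000 nM.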

Compound 4, concentration for 50% growth inhibition: > 100000 nM
Compound 4 gave a limit, no number; the forecaster's own chance of this, stated with the estimate: 5%; middle value at least 12-fold (1.09 log units) away from the limit.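

In this assay compound 4 gives > 100000 nM, which is a limit of the assay and not a number. The change from methyl to 1H-pyrrol-2-yl therefore reads as an at least 10-fold higher number from compound 1 to compound 4 (1.04 log units; beyond the scatter), a floor rather than an exact size, and it shows that this position between two ring nitrogen atoms is sensitive to the group it carries, something the earlier swaps of trifluoromethyl could not reveal. Compound 4 now sits at the same limit as compound 2: the limit of > 100000 nM in this assay, at which 2 of the 4 values shown sit.

Going by these compounds, the true size of this step stays open, and a single change does not separate the effect of the added ring from that of its hydrogen-bond donor. On these data alone, whether a smaller change at this position, such as an ethyl chain, or a phenyl ring, which has no such donor, would be tolerated also remains open.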